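The source may hold more compounds than are shown below. What is called first, only, known or untested is meant among the compounds shown, and "the series" means these compounds.

In a functional assay on CHO-K1 cells for agonist activity at somatostatin receptor type 2 (Homo sapiens), read by cAMP accumulation, with a stated time of 30 min (on this read-out lower numbers stand for an effect already at smaller amounts and higher numbers for an effect only at larger amounts of compound), compound 1 `Cc1cc(C)cc(-c2cncc(-c3nc4cc(C(F)(F)F)ccc4[nH]3)c2N2CCC(N)CC2)c1` gives 0.014 nM, the lowest of the two numbers in hand. Compound 2 `Cc1cc(C(=O)Nc2cncc(-c3cc(Cl)cc(Cl)c3)c2N2CCC(N)CC2)n(C)n1` gives 0.041 nM in this assay, a higher number that lies beyond the scatter of the measurement; the two compounds differ in more than one place, so the gap between them shows only what the two values show. Compound 3 `Cc1cc(C)cc(-c2cncc(-c3nc4cc(C)ccc4[nH]3)c2N2CCC(N)CC2)c1` has not yet been measured. It differs from compound 1 in one place: methyl in place of trifluoromethyl on an aromatic carbon. For the measured compounds named here, no measured pair carries this change, so the expectation rests on the values of compound 1 and compound 2 alone. The change is expected to shift the number only a little, if at all, with a slight lean toward a higher number: a 1.8-fold higher number from compound 1 to compound 3 (0.25 log units; within the scatter). Compound 3 is accordingly expected to give 0.025 nM in this assay, with a range from 0.008 nM to 0.08 nM.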

Compound 3, half-maximal effective concentration: 0.013 nM
The estimate for compound 3 lay 1.9-fold (0.28 log units) above the measured number, and the stated range covers the measured number.
By their numbers in this assay, from the lowest: compounds 3 and 1 (each within the scatter of the next); then compound 2.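

In this assay, for the compounds shown here, methyl in place of trifluoromethyl on this aromatic carbon gives a 1.1-fold lower number from compound 1 to compound 3 (0.03 log units; within the scatter), the first step that changes one place only. On this read-out, compound 1 and compound 3 cannot be told apart, so the fluorine atoms of trifluoromethyl are not needed at this position for a number in this range, at least with the rest of compound 1 in place. No evidence at hand accounts for the two groups reading alike.

Still open, from the compounds shown here alone, is how this carbon responds to groups of another kind, such as an amine, a carboxylic acid, a methoxy group or a longer chain, as methyl and trifluoromethyl are the only two seen here. Also open, going by these compounds, is whether the two groups would read alike on any other read-out.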